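From a Propanoyl Ester to an Aromatic Ester

The source may report more compounds than this note shows. Statements on the series, on what has been measured and on what is new or still open speak of the compounds shown alone.

In a functional assay on HepG2 cells (Homo sapiens) for cytotoxicity, read by MTT assay (on this read-out lower numbers stand for stronger inhibition and higher numbers for weaker inhibition), compound 1 (`COc1ccc(/C=C/C(=O)c2ccc(OC)c3c2OC(C)(C)C=C3)cc1O`) gives 450 nM. Compound 2 (`C=CCOc1cc(/C=C/C(=O)c2ccc(OC)c3c2OC(C)(C)C=C3)ccc1OC`) reaches only a limit, > 10000 nM. Compound 3 (`CCC(=O)Oc1cc(/C=C/C(=O)c2ccc(OC)c3c2OC(C)(C)C=C3)ccc1OC`) gives 90 nM, the lowest number of the three.

Compound 4 (`COc1cccc(C(=O)Oc2cc(/C=C/C(=O)c3ccc(OC)c4c3OC(C)(C)C=C4)ccc2OC)c1`) differs from compound 3 by one change: 3-methoxyphenyl in place of ethyl on a carbonyl carbon. The measured steps bearing on this are changes on the same oxygen. Of these, a 5.0-fold lower number from compound 1 to compound 3 (0.70 log units; beyond the scatter) is modest, while an at least 22-fold higher number from compound 1 to compound 2 (1.34 log units; beyond the scatter) and an at least 110-fold lower number from compound 2 to compound 3 (2.04 log units; beyond the scatter) are large. None of them tests an aromatic group on the carbonyl carbon, so the direction is uncertain.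

In this assay, a modest rise is tentatively expected, a 3.3-fold higher number from compound 3 to compound 4 (0.52 log units; beyond the scatter). For compound 4, the estimated value is 300 nM, within an expected range of 60 nM to 2500 nM.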

Compound 4, half-maximal inhibitory concentration: 870 nM
The estimate for compound 4 lay 2.9-fold (0.46 log units) below the measured number, and the stated range covers the measured number.
By their numbers in this assay, from the lowest: compound 3; then compounds 1 and 4 (each within the scatter of the next). At a limit, above all of these: compound 2.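

In this assay, an aromatic group on the carbonyl carbon does not keep the low number of the propanoyl ester: 3-methoxyphenyl in place of ethyl gives a 9.7-fold higher number from compound 3 to compound 4 (0.99 log units; beyond the scatter). Against the free hydroxyl, the aromatic ester shows a 1.9-fold higher number from compound 1 to compound 4 (0.29 log units; within the scatter), so these two are not separated. Against the allyl ether the result is an at least 11-fold lower number from compound 2 to compound 4 (1.06 log units; beyond the scatter), a step that rests on a limit for compound 2, not a number: the limit of > 10000 nM in this assay, at which 1 of the 4 values shown sits.

The compounds shown leave open whether the ring itself or its methoxy group sets this number. They also leave open how a plain phenyl or a longer chain such as butyl on the carbonyl carbon would read.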